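This account rests on a few compounds, and the source may have more. Where it says the series, first, only, none or still open, it means among the compounds named here.

Compound 1 `Cc1noc(C)c1-c1cnc(N)c(Oc2ccc(C(=O)Nc3ccccc3)cc2)n1` gives 11800 nM in a functional assay on HepG2 cells (Homo sapiens) for inhibition, read by MTT assay, with a stated time of 72 h; on this read-out lower numbers stand for stronger inhibition and higher numbers for weaker inhibition. Compound 2 `Cc1noc(C)c1-c1cnc(N)c(Oc2ccc(C(=O)Nc3cc(Cl)ccn3)cc2)n1` gives > 100000 nM in this assay, which is a limit rather than a number.

Compound 1 thus holds the only number shown. Within the data shown here, the step of an at least 8.4-fold higher number from compound 1 to compound 2 (0.92 log units; beyond the scatter) is the one measured change; it rests on (the limit of > 100000 nM in this assay, at which 1 of the 2 values shown sits). Compound 3 `Cn1cc(-c2cnc(N)c(Oc3ccc(C(=O)Nc4ccccc4)cc3)n2)cn1` differs from compound 1 by 1-methyl-1H-pyrazol-4-yl in place of 3,5-dimethyl-1,2-oxazol-4-yl on an aromatic carbon. The measured step concerns the amide-type nitrogen, not this aromatic carbon, so no step shown bears on it, and no change beyond the scatter is expected. Compound 3 is estimated at 12000 nM (range 4000 nM to 40000 nM), an expected step of a 1.0-fold higher number from compound 1 to compound 3 (0.01 log units; within the scatter).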

Compound 3, half-maximal inhibitory concentration: 11600 nM
Estimate against measurement, compound 3: 1.0-fold (0.01 log units) above, within the range that was stated.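

Two different five-membered aromatic rings on this aromatic carbon are not told apart in this assay, with a 1.0-fold lower number from compound 1 to compound 3 (0.01 log units; within the scatter). The earlier compounds spoke only to the amide-type nitrogen, so this is the first reading at this carbon, and the 3,5-dimethyl-1,2-oxazol-4-yl group is shown not to be required for the value seen with compound 1. Nothing shown explains this outcome. Still open, from the compounds shown here alone, is whether a morpholine or a simple amine at this carbon would hold the value, and whether a longer chain in place of the methyl on the pyrazole would do so.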